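The source may report more compounds than this note shows. Statements on the series, on what has been measured and on what is new or still open speak of the compounds shown alone.

Working notes on the series, inhibition of topoisomerase 1.

Two compounds have numbers in an assay on isolated protein for inhibition of DNA topoisomerase 1 (Homo sapiens), tested at 100 uM; on this read-out lower numbers stand for a weaker effect and higher numbers for a stronger effect at the one concentration tested. Compound 1 `Clc1ccc(-c2cc(-c3ccsc3)nc(-c3ccco3)c2)o1` gives 8.2% in this assay. Compound 2 `Cc1ccc(-c2cc(-c3ccc(Cl)o3)cc(-c3cccs3)n2)cc1` gives 41.8% in this assay, the higher of the two, and the gap to compound 1 lies beyond the scatter. Compounds 1 and 2 differ in more than one place, so the gap between them cannot be assigned to any single change.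

The next compound, compound 3 `Cc1ccc(-c2cc(-c3ccc(Cl)o3)cc(-c3ccsc3)n2)cc1`, has the same atoms as compound 2 joined differently: thiophen-3-yl in place of thiophen-2-yl on an aromatic carbon. The change sits on an aromatic carbon of a six-membered aromatic ring with 1 nitrogen, next to the ring nitrogen, meta to a 4-methylphenyl group and meta to a 5-chlorofuran-2-yl group.

For the measured compounds named here, no pair of measured compounds isolates this change. Compound 1, which carries thiophen-3-yl but also differs elsewhere, gives 8.2% in this assay, which is the only hint available. Because compound 2 stands at 41.8%, compound 3 is expected to give 30% in this assay, within 10% to 50%. The expected step from compound 2 to compound 3 in this assay is a number 11.8 percentage points lower from compound 2 to compound 3 (beyond the scatter), a modest decrease, with a step of no size beyond the scatter also plausible.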

Compound 3, a percentage reported as inhibition, at one concentration (the size of the read-out at that concentration, not a potency): 2.6%
Compound 3: middle estimate off by 27.4 percentage points, on the high side; measured number outside the range, below it.
By their numbers in this assay, from the lowest: compounds 3 and 1 (each within the scatter of the next); then compound 2.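

On the aromatic carbon next to the ring nitrogen, the attachment point of the thiophene alone matters in this assay: thiophen-3-yl in place of thiophen-2-yl gives a number 39.2 percentage points lower from compound 2 to compound 3 (beyond the scatter), a large step between two compounds with the same atoms. With thiophen-3-yl held constant, 4-methylphenyl in place of furan-2-yl gives a number 5.6 percentage points lower from compound 1 to compound 3 (within the scatter), so in this pair that exchange produces no step beyond the scatter, and thiophen-2-yl remains the only feature tied by a single change to the higher number. No measurement here bears on why the thiophene attachment point has so large an effect.

The compounds shown leave open whether thiophen-2-yl would also give a large step over thiophen-3-yl with furan-2-yl in place of 4-methylphenyl, so the step seen here is established only with the 4-methylphenyl group present. From the compounds shown here alone, it is also open how this read-out would respond to furan-2-yl at the thiophene position, or to an amine or a carboxylic acid in place of the methyl of the 4-methylphenyl group.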